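Iodo for Chloro Across Two Unrelated Cores

The compounds below may be only part of what the source reports. "The series", "measured", "known", "first", "only" and "open" are said of these compounds alone.

Compound 1 `O=C1O/C(=C\Cn2cc(Cl)c(=O)[nH]c2=O)C(OCc2ccccc2)=C1OCc1ccccc1` and compound 2 `O=C1O/C(=C\Cn2cc(I)c(=O)[nH]c2=O)C(OCc2ccccc2)=C1OCc1ccccc1` share one core; compound 3 `CC(=O)OCCOCn1cnc2c(Cl)nc(Cl)nc21` and compound 4 `CC(=O)OCCOCn1cnc2c(Cl)nc(I)nc21` share another, and the difference between the two cores is not broken down here. In an ADME assay on L1210/0 cells (Mus musculus) for cytotoxicity, with a stated time of 48 h (on this read-out lower numbers stand for stronger inhibition and higher numbers for weaker inhibition), compound 1 gives 12200 nM and compound 2 gives 7500 nM. The step of a 1.6-fold lower number from compound 1 to compound 2 (0.21 log units; within the scatter) follows the change (iodo in place of chloro on an aromatic carbon). In this assay compound 3 gives 39300 nM, the highest of the three numbers. Compound 4 is not yet measured; it differs from compound 3 by iodo in place of chloro on an aromatic carbon, the same kind of change, though here the carbon lies between two ring nitrogen atoms, meta to a chloro group, meta and para to a fused ring of a system of two rings, whereas in compound 2 it is two atoms from the ring nitrogen, ortho to a group of 1 heavy atom and para to another. The earlier step of a 1.6-fold lower number from compound 1 to compound 2 (0.21 log units; within the scatter) stayed within the scatter, and a step of that size is expected again, a 1.4-fold lower number from compound 3 to compound 4 (0.15 log units; within the scatter). Compound 4 is estimated at 28000 nM in this assay, with a range from 12000 nM to 65000 nM.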

Compound 4, half-maximal inhibitory concentration: 8600 nM
Estimate against measurement, compound 4: 3.3-fold (0.51 log units) above; measured number outside the range, below it.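

In this assay, iodo in place of chloro on an aromatic carbon gives a 4.6-fold lower number from compound 3 to compound 4 (0.66 log units; beyond the scatter), so the change does not carry from one core to the other at a single size, and the two steps differ: the same change on two cores in this assay, a 1.6-fold lower number (0.21 log units; within the scatter) from compound 1 to compound 2 and a 4.6-fold lower number (0.66 log units; beyond the scatter) from compound 3 to compound 4, 2.8-fold (0.45 log units) apart, beyond the scatter of two such steps. Going by these compounds alone, only the step on the core of compound 3 lies beyond the scatter, while the step on the core of compound 1 lies within it, so these two pairs establish no shared direction for the change. The comparison does not show what sets the steps apart, since the carbon between two ring nitrogen atoms in compound 4 and the rest of each core vary together, and two pairs give no rule for a third core.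

Open, going by these compounds, is whether bromo on that same carbon of the core of compound 3 would give a number nearer that of the chloro or the iodo compound. Also open, on these data alone, is whether the step would hold with an amine in place of the chloro group that remains in compound 4.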